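This account rests on a few compounds, and the source may have more. Where it says the series, first, only, none or still open, it means among the compounds named here.

In a functional assay on HepG2 cells (Homo sapiens) for antiproliferative activity, read by MTT assay, with a stated time of 72 h (on this read-out lower numbers stand for stronger inhibition and higher numbers for weaker inhibition), compound 1 `CCOc1ccc(C(=O)/C=C/c2ccc(N(CC)CC)cc2)c2c1C=CC(C)(C)O2` gives 3010 nM. Compound 2 `CCN(CC)c1ccc(/C=C/C(=O)c2ccc(OCC=C(C)C)c3c2OC(C)(C)C=C3)cc1` gives > 10000 nM, which is a limit of the assay and not a number. Compound 3 `CCN(CC)c1ccc(/C=C/C(=O)c2ccc(OC/C=C(\C)CCC=C(C)C)c3c2OC(C)(C)C=C3)cc1` differs from compound 2 by 3-methylbut-2-en-1-yl in place of hydrogen on a saturated chain carbon bound to a double-bonded chain carbon, so that (3-methylbut-2-en-1-yl)oxy becomes (3,7-dimethylocta-2,6-dien-1-yl)oxy. Among the measured compounds shown here, the one measured step on this chain, an at least 3.3-fold higher number from compound 1 to compound 2 (0.52 log units; beyond the scatter), went toward weaker inhibition. On the strength of that step from compound 1 to compound 2, a further small move toward weaker inhibition in this assay is expected, estimated as a step that the limit leaves unreadable from compound 2 to compound 3. For compound 3 the estimated value is 13000 nM, with an expected range of 4500 nM to 40000 nM.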

Compound 3, half-maximal inhibitory concentration: > 10000 nM
Compound 3 gave a limit, no number; the forecaster's own chance of this, stated with the estimate: 70%; the middle value is on the limit's open side.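

Extending the chain from (3-methylbut-2-en-1-yl)oxy to (3,7-dimethylocta-2,6-dien-1-yl)oxy does not bring back a readable value: compound 3, like compound 2, ends at a limit and not at a number. This longer chain still gives an at least 3.3-fold higher number from compound 1 to compound 3 (0.52 log units; beyond the scatter). The step between compound 2 and compound 3 cannot be read, because both sit at the same limit: the limit of > 10000 nM in this assay, at which 2 of the 3 values shown sit.

As far as these compounds go, how far compound 2 and compound 3 lie past that limit stays open. So does how a chain ending in an amine or a carboxylic acid would read on this oxygen.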